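Notes on a cytotoxic series: methylamino in place of arylamino

This account rests on a few compounds, and the source may have more. Where it says the series, first, only, none or still open, it means among the compounds named here.

The series shares one core, seen in compound 1 `N[C@H]1CC[C@H](Nc2c(C(=O)NCc3ccc(F)cc3)nc(N3CCCCS3(=O)=O)c3cccnc23)CC1`, compound 2 `N[C@H]1CC[C@H](Nc2c(C(=O)NCc3ccco3)nc(Br)c3cccnc23)CC1` and compound 3 `Nc1ccc(Nc2c(C(=O)NCc3ccc(F)cc3)nc(Br)c3cccnc23)cc1`. In a functional assay on HCT-116 cells (Homo sapiens) for cytotoxicity, read by MTT assay, with a stated time of 72 h (a lower number here means a stronger inhibitor, a higher number a weaker inhibitor), compound 3 gives 10000 nM, the only number among the three results shown, so compound 3 stands alone as the reference point. For compound 1 the result in this assay is a limit of the assay, > 10000 nM. For compound 2 the result in this assay is likewise a limit, > 10000 nM. Going by the values given here, no two measured compounds differ in a single place, so no measured step can be read here; the only further information is the limit of > 10000 nM in this assay, at which 2 of the 3 values shown sit.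

Compound 4 `CNc1c(C(=O)NCc2ccc(F)cc2)nc(Br)c2cccnc12` is not yet measured. Relative to compound 3, the change is methyl in place of 4-aminophenyl on a nitrogen on an aromatic ring. Among the compounds with values here, with no measured step to lean on, the expectation is for a change in this assay of about a 1.5-fold higher number from compound 3 to compound 4 (0.18 log units; within the scatter), toward weaker inhibition if anything, with a fair chance that only a limit is reported. Compound 4 is therefore expected to give roughly 15000 nM in this assay, somewhere between 5000 nM and 50000 nM.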

Compound 4, half-maximal inhibitory concentration: > 20000 nM
Compound 4: a limit, no number (the forecaster's own chance of this, stated with the estimate: 60%); at least 1.3-fold (0.12 log units) between middle value and limit.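

In this assay, methyl in place of 4-aminophenyl on a nitrogen on an aromatic ring gives an at least 2.0-fold higher number from compound 3 to compound 4 (0.30 log units; that floor lies within the scatter). The result for compound 4 is a limit of the assay and not a number, so the step has a floor but no measured size: the limit of > 20000 nM in this assay, at which 1 of the 4 values shown sits.

Going by these compounds alone, this is the first step that can be read, and the change from (4-aminophenyl)amino to methylamino shows no sign of stronger inhibition, though a real loss cannot be separated from the scatter at that floor.

Open, going by these compounds, is whether phenyl without its amine, or a longer chain such as butyl ending in an amine, on that nitrogen would return a number rather than a limit. Also open, on these data alone, is how the change would read with the other groups of the shared core altered.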